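Adding a methyl to the anilino ring of compound 3

The source may hold more compounds than are shown below. What is called first, only, known or untested is meant among the compounds shown, and "the series" means these compounds.

The compounds share one core, an aminothiazole carrying a cinnamoyl arm; compound 1 `Cc1nc(Nc2ccc(Cl)c(Cl)c2)sc1C(=O)/C=C/c1ccccc1` bears a 3,4-dichlorophenyl on the amine nitrogen and in a functional assay on PC-3 cells (Homo sapiens) for cytotoxicity, read by MTT assay (on this read-out lower numbers stand for stronger inhibition and higher numbers for weaker inhibition), compound 1 gives 7990 nM. Compound 3 `Cc1nc(Nc2ccccc2)sc1C(=O)/C=C/c1ccccc1` carries a plain phenyl there. In this assay compound 3 reaches only the limit of > 25000 nM, not a number. Compound 2 `Cc1ccc(Nc2nc(C)c(C(=O)/C=C/c3ccc(Cl)cc3)s2)cc1` likewise stops at the limit of > 25000 nM in this assay. Compound 3 therefore sits among the weakest values shown, at the line where (the limit of > 25000 nM in this assay, at which 2 of the 3 values shown sit).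

Compound 4 `Cc1ccc(Nc2nc(C)c(C(=O)/C=C/c3ccccc3)s2)cc1` differs from compound 3 by methyl in place of hydrogen on an aromatic carbon, so the anilino becomes a (4-methylphenyl)amino. Within the data shown here, the only measured step on this part of the molecule is an at least 3.1-fold higher number from compound 1 to compound 3 (0.49 log units; beyond the scatter), which runs toward weaker inhibition when the halogens are removed. Among the measured compounds shown here, a small methyl added to that ring gives no step of its own to lean on, and compound 2, which carries the same methyl, also reached only the limit. The expected step is therefore a step that the limit leaves unreadable from compound 3 to compound 4, none beyond the scatter. Compound 4 is estimated at 30000 nM, with a range from 12000 nM to 75000 nM.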

Compound 4, half-maximal inhibitory concentration: > 25000 nM
Compound 4 ended at the assay's limit; the forecaster's own chance of this, stated with the estimate: 80%; the middle value lies beyond the limit too.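

In this assay, replacing the 3,4-dichlorophenyl of compound 1 with a 4-methylphenyl gives an at least 3.1-fold higher number from compound 1 to compound 4 (0.49 log units; beyond the scatter). A methyl on this ring therefore does not restore a measurable value, so a second ring without chlorines joins compound 3 in losing the activity seen with compound 1. Among these compounds, the steps from compound 3 to compound 4 and from compound 2 to compound 4 cannot be read, and compound 1 remains the only compound with an actual number, while the others stop at one assay limit: the limit of > 25000 nM in this assay, at which 3 of the 4 values shown sit.

Whether the methyl changes activity at all stays hidden behind that limit. Also open, going by these compounds, is how a single chloro or a methoxy on that ring would compare with the two chlorines of compound 1.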